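Urea series on the shared core: 3,4-dichlorophenyl to 3-(trifluoromethyl)phenyl

The source may report more compounds than this note shows. Statements on the series, on what has been measured and on what is new or still open speak of the compounds shown alone.

Measured so far:
compound 1 `COc1cc(Cl)cc(-c2nn(-c3cccc(NC(=O)Nc4cc(C(F)(F)F)cc(C(F)(F)F)c4)c3)cc2-c2ccncc2)c1` — 90%
compound 2 `COc1cc(Cl)cc(-c2nn(-c3cccc(NC(=O)Nc4ccc(Cl)c(Cl)c4)c3)cc2-c2ccncc2)c1` — 53%

In a functional assay on HCT-15 cells (Homo sapiens) for inhibition, read by sulforhodamine B assay, with a stated time of 48 h, tested at 0.1 uM (a higher number here means a weaker effect of the compound at the concentration tested, a lower number a stronger effect), compound 2 stands lowest of the two numbers, with compound 1 giving a number well above it, beyond the scatter. Compound 3 `COc1cc(Cl)cc(-c2nn(-c3cccc(NC(=O)Nc4cccc(C(F)(F)F)c4)c3)cc2-c2ccncc2)c1` is not yet measured. It differs from compound 2 at the amide-type nitrogen whose other neighbour is the carbonyl carbon: 3-(trifluoromethyl)phenyl in place of 3,4-dichlorophenyl on an amide-type nitrogen. Within the data shown here, no step between measured compounds is available for this exact change. With compound 1 at 90%, a move back towards a higher number is expected, of moderate size: a step of a number 19 percentage points higher from compound 2 to compound 3 (beyond the scatter) in this assay, judged beyond the scatter. Compound 3 is therefore estimated at 72%, with a range from 50% to 92%.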

Compound 3, a percentage reported as activity, at one concentration (the size of the read-out at that concentration, not a potency): 83%
Compound 3: middle estimate off by 11 percentage points, on the low side; the range from low to high includes it.
By their numbers in this assay, from the lowest: compound 2; then compounds 3 and 1 (each within the scatter of the next).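

In this assay, among these compounds, 3-(trifluoromethyl)phenyl in place of 3,4-dichlorophenyl gives a number 30 percentage points higher from compound 2 to compound 3 (beyond the scatter) on this amide-type nitrogen, the first direct reading of a single change at this place. Hydrogen in place of trifluoromethyl on an aromatic carbon gives a number 7 percentage points lower from compound 1 to compound 3 (within the scatter) and so the second trifluoromethyl makes no readable difference here. Nothing available bears on the cause of either step. Open, from the compounds shown here alone, is whether a methoxy group, an amine or a carboxylic acid on this phenyl ring, in place of the two chlorines, gives a number nearer compound 2 or compound 3.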